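Trifluoromethyl to ethyl on the shared core

The compounds below may be only part of what the source reports. "The series", "measured", "known", "first", "only" and "open" are said of these compounds alone.

In a functional assay on the whole organism (brain) with Mus musculus as the target (a higher number here means that more compound is needed for the effect, a lower number that less compound is needed), compound 1 (`O=[N+]([O-])c1ccc(OCCc2c[nH]cn2)cc1`) gives 0.66 mg/kg. Compound 2 (`FC(F)(F)c1ccc(OCCc2c[nH]cn2)cc1`) stands at > 10 mg/kg, which is a limit of the assay and not a number. Going by the values given here, the one measured step, an at least 15-fold higher number from compound 1 to compound 2 (1.18 log units; beyond the scatter), also falls on an aromatic carbon and is large, but it does not involve ethyl. Compound 3 (`CCc1ccc(OCCc2c[nH]cn2)cc1`) carries ethyl in place of trifluoromethyl on an aromatic carbon. A modest move toward less compound needed is expected, and another limit remains possible. The expected step is an at least 1.6-fold lower number from compound 2 to compound 3 (0.22 log units; that floor lies within the scatter). Compound 3 is estimated at 6 mg/kg, with an expected range of 1.5 mg/kg to 20 mg/kg.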

Compound 3, dose for half-maximal effect: > 10 mg/kg
Compound 3: a limit, no number; the forecaster's own chance of this, stated with the estimate: 35%; middle value at least 1.6-fold (0.22 log units) from the limit.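

In this assay, replacing nitro with ethyl gives an at least 15-fold higher number from compound 1 to compound 3 (1.18 log units; beyond the scatter), so a large step now appears with two different replacements of nitro at this position, one of them free of fluorine. The step from compound 2 to compound 3 cannot be read, and any difference between trifluoromethyl and ethyl stays hidden at the edge of the read-out: the limit of > 10 mg/kg in this assay, at which 2 of the 3 values shown sit.

Still open, from the compounds shown here alone, is whether a nitrile or an amine at this position would give a number within the range of the assay, as nitro does in compound 1.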